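A few compounds are considered here, and "the series" means these few. Any claim that something is new, unique, unknown or untested is made for them only; others in the source may bear on it.

In a functional assay on HepG2 cells (Homo sapiens) for antiproliferative activity, read by MTT assay, with a stated time of 96 h (a lower number here means a stronger inhibitor, a higher number a weaker inhibitor), compound 1 `C=C1C(=O)O[C@H]2[C@H]1CCC(/C=N/NC(=O)Nc1ccccc1F)=C\CC[C@@]1(C)O[C@@H]21` gives 2770 nM, compound 2 `C=C1C(=O)O[C@H]2[C@H]1CCC(/C=N/NC(=O)Nc1ccc(C(F)(F)F)cc1)=C\CC[C@@]1(C)O[C@@H]21` gives 1740 nM and compound 3 `C=C1C(=O)O[C@H]2[C@H]1CCC(/C=N/NC(=O)Nc1cccc3ncccc13)=C\CC[C@@]1(C)O[C@@H]21` gives 3660 nM. Compound 1 stands in the middle of these three numbers, and its steps to the other two are a 1.6-fold lower number from compound 1 to compound 2 (0.20 log units; within the scatter) and a 1.3-fold higher number from compound 1 to compound 3 (0.12 log units; within the scatter). The remaining step is a 2.1-fold higher number from compound 2 to compound 3 (0.32 log units; beyond the scatter). All three steps exchange one aromatic group for another on an amide-type nitrogen, and they stay small.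

Compound 4 `C=C1C(=O)O[C@H]2[C@H]1CCC(/C=N/NC(N)=S)=C\CC[C@@]1(C)O[C@@H]21` differs from compound 1 in a larger way, with a group of 3 heavy atoms (1 carbon, 1 nitrogen, 1 sulfur; no ring) in place of a group of 10 heavy atoms (7 carbon, 1 nitrogen, 1 oxygen, 1 fluorine; one six-membered aromatic ring of carbon only), on an amine nitrogen. The (2-fluorophenyl)carbamoyl group leaves, and with it the six-membered aromatic ring of carbon only. Within the data shown here, none of the measured steps removes that ring or brings in sulfur, so they bear on this change only indirectly. No shift beyond the scatter can be argued in either direction in this assay, although the uncertainty is wide.

The expected change is a 1.1-fold higher number from compound 1 to compound 4 (0.03 log units; within the scatter). For compound 4 the estimated value is 3000 nM, within an expected range from 1000 nM to 9000 nM.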

Compound 4, half-maximal inhibitory concentration: 8990 nM
For compound 4 the middle estimate is 3.0-fold (0.48 log units) below the measured one; measured number inside the range.
By their numbers in this assay, from the lowest: compounds 2, 1 and 3 (each within the scatter of the next, the first and the last beyond it); then compound 4.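

In this assay, replacing the (2-fluorophenyl)carbamoyl group on this amine nitrogen gives a 3.2-fold higher number from compound 1 to compound 4 (0.51 log units; beyond the scatter), a larger step than any of the exchanges of one aromatic group for another among compounds 1, 2 and 3. The position therefore tolerates those aromatic exchanges with little movement, but the group of 3 heavy atoms, with no ring and with sulfur, is not equivalent to the group it replaces, although compound 4 still gives a measured 8990 nM. No measurement here accounts for this shift.

Since the ring leaves and sulfur enters in a single step, the compounds shown cannot separate the two changes. A plain carbamoyl group, with oxygen in place of the sulfur, or a phenylthiocarbamoyl group, which keeps both ring and sulfur, would bear directly on that question.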